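The source may hold more compounds than are shown below. What is called first, only, known or untested is meant among the compounds shown, and "the series" means these compounds.

Of the compounds shown here, three sharing one core have been tested in an assay on isolated protein for inhibition of malate dehydrogenase, mitochondrial (Sus scrofa), with stated times of 45 min and 30 min; a lower number here means a stronger inhibitor, a higher number a weaker inhibitor. Compound 1, `COc1ccc(Cl)cc1S(=O)(=O)Nc1ccc(-c2nc3ccccc3o2)cc1`, gives only a limit of the assay, > 63000 nM. Compound 2, `O=S(=O)(Nc1ccc(-c2nc3ccccc3o2)cc1)c1cccc(O)c1`, likewise gives only a limit, > 63000 nM. Compound 3, `O=S(=O)(Nc1ccc(-c2nc3ccccc3o2)cc1)c1ccccc1Cl`, gives only a limit as well, > 63000 nM. All three values sit at the same limit (the limit of > 63000 nM in this assay, at which 3 of the 3 values shown sit), so the steps among them cannot be read: a step that the two limits leave unreadable from compound 1 to compound 2, a step that the two limits leave unreadable from compound 1 to compound 3 and a step that the two limits leave unreadable from compound 2 to compound 3. Compound 3 therefore stands at the limit, no different from the others as far as the numbers show.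

Compound 4, `CS(=O)(=O)Nc1ccc(-c2nc3ccccc3o2)cc1`, is the next compound to be measured in this assay. It differs from compound 3 as follows: methyl in place of 2-chlorophenyl on a sulfonyl sulfur. Each measured step swapped one substituent on the sulfonyl sulfur for another, and none was readable, so they give no size for the coming step in either direction. With every change so far leaving the value at the limit (the limit of > 63000 nM in this assay, at which 3 of the 3 values shown sit), the step expected here, a step that the limit leaves unreadable from compound 3 to compound 4, is one of no readable movement. Compound 4 is estimated at 100000 nM, within a range of 30000 nM to 500000 nM, most probably again only a limit.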

Compound 4, half-maximal inhibitory concentration: > 63000 nM
Compound 4: a limit, no number (the forecaster's own chance of this, stated with the estimate: 85%); the middle value does not contradict the limit.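

Compound 4 joins compound 1, compound 2 and compound 3 at a limit, so no step among these four compounds can be read: the limit of > 63000 nM in this assay, at which 4 of the 4 values shown sit.

The compounds shown leave open whether any group on the sulfonyl sulfur gives a measurable value in this assay.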